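Swapping the sulfur of a thiocyanate for selenium

A few compounds are considered here, and "the series" means these few. Any claim that something is new, unique, unknown or untested is made for them only; others in the source may bear on it.

Measured compounds:
compound 1, `C[Se]c1ccc2ccccc2n1`: > 100000 nM
compound 2, `Cc1noc(C)c1CSC#N`: 13800 nM

In a functional assay on PC-3 cells (Homo sapiens) for cytotoxicity, read by MTT assay, with a stated time of 72 h (on this read-out lower numbers stand for stronger inhibition of growth and higher numbers for weaker inhibition of growth), compound 1 gives > 100000 nM, which is a limit of the assay rather than a number (the limit of > 100000 nM in this assay, at which 1 of the 2 values shown sits). Going by the values given here, compound 2 gives 13800 nM in this assay, and it stands as the only true number here.

Compound 3, `Cc1noc(C)c1C[Se]C#N`, has not yet been measured. It differs from compound 2 by a group of 3 heavy atoms (1 carbon, 1 nitrogen, 1 selenium; no ring) in place of a group of 3 heavy atoms (1 carbon, 1 nitrogen, 1 sulfur; no ring), on a saturated chain carbon bound to an aromatic carbon. Among the compounds with values here, no measured pair shows what this kind of swap does, so the expectation rests on the single number of compound 2 alone. A change of a single heavy atom within the same small group is expected to shift the growth inhibition only modestly, with no clear direction beyond the usual scatter.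

Compound 3 is therefore expected to give about 9000 nM in this assay, within a range from 2500 nM to 35000 nM. That amounts to an expected step of a 1.5-fold lower number from compound 2 to compound 3 (0.19 log units; within the scatter).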

Compound 3, concentration for total growth inhibition: 10300 nM
Compound 3: middle estimate off by 1.1-fold (0.06 log units), on the low side; the measured number falls inside the stated range.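

In this assay, exchanging sulfur for selenium in the group on a saturated chain carbon bound to an aromatic carbon gives a 1.3-fold lower number from compound 2 to compound 3 (0.13 log units; within the scatter). Going by these compounds alone, this is the first pair of measured compounds that differ in one place, and it shows that, at this position and on this core, the read-out does not separate the sulfur group from the selenium group. Nothing measured here speaks to why the two compounds read alike.

Still open, as far as these compounds go, is whether the cyanosulfanyl group or its selenium counterpart matters for growth inhibition at all, since an amine or a carboxylic acid at the same place could show how much this position tolerates. Also open, from the compounds shown here alone, is whether the same exchange of one atom would read the same way on a longer chain or on another core.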